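The compounds below may be only part of what the source reports. "The series", "measured", "known", "first", "only" and "open" are said of these compounds alone.

Compound 3, `COc1cc2oc(-c3ccccc3)cc(=O)c2c(O)c1OCCCCN1CCCC1`, gives 4900 nM in a functional assay on HepG2 cells (Homo sapiens) for antiproliferative activity, read by MTT assay, with a stated time of 48 h; a higher number here means a weaker inhibitor, a lower number a stronger inhibitor. Compound 1, `CCN(CC)CCCCOc1c(OC)cc2oc(-c3ccccc3)cc(=O)c2c1O`, differs from it by diethylamino in place of pyrrolidin-1-yl on a saturated chain carbon, four bonds along the chain from an oxygen on an aromatic ring and gives 7100 nM in this assay, so the step is a 1.4-fold higher number from compound 3 to compound 1 (0.16 log units; within the scatter). Compound 2, `O=c1cc(-c2ccccc2)oc2cc(OCc3ccccc3)c(OCCCCN3CCCC3)c(O)c12`, shares the core of compound 3 but carries phenyl in place of hydrogen on a saturated chain carbon bound to an oxygen on an aromatic ring; in this assay compound 2 gives 2000 nM, the lowest of the three numbers, and the step is a 2.5-fold higher number from compound 2 to compound 3 (0.39 log units; beyond the scatter). Compound 4, `CCN(CC)CCCCOc1c(OCc2ccccc2)cc2oc(-c3ccccc3)cc(=O)c2c1O`, has not yet been measured. It differs from compound 2 by diethylamino in place of pyrrolidin-1-yl on a saturated chain carbon, four bonds along the chain from an oxygen on an aromatic ring, and the place of the change reads the same, word for word, as the place of the change from compound 3 to compound 1, so it is the same change made on the core of compound 2. Since that change gave a 1.4-fold higher number from compound 3 to compound 1 (0.16 log units; within the scatter), the step from compound 2 to compound 4 is expected to be about a 1.4-fold higher number from compound 2 to compound 4 (0.15 log units; within the scatter) in this assay, which would leave it within the scatter of compound 2. Compound 4 is therefore estimated at 2800 nM, between 1400 nM and 5600 nM.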

Compound 4, half-maximal inhibitory concentration: 2200 nM
Beside the measured number, compound 4's estimate is 1.3-fold (0.10 log units) above it; measured number inside the range.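

In this assay, diethylamino in place of pyrrolidin-1-yl on the core of compound 2 gives a 1.1-fold higher number from compound 2 to compound 4 (0.04 log units; within the scatter), and this step agrees with the same change on the core of compound 3: the same change on two cores in this assay, a 1.4-fold higher number (0.16 log units; within the scatter) from compound 3 to compound 1 and a 1.1-fold higher number (0.04 log units; within the scatter) from compound 2 to compound 4, 1.3-fold (0.12 log units) apart, within the scatter of two such steps The second change, phenyl in place of hydrogen on a saturated chain carbon bound to an oxygen on an aromatic ring, gives a 3.2-fold lower number from compound 1 to compound 4 (0.51 log units; beyond the scatter) and also carries over, its size holding with diethylamino as with pyrrolidin-1-yl: the same change on two cores in this assay, a 2.5-fold higher number (0.39 log units; beyond the scatter) from compound 2 to compound 3 and a 3.2-fold higher number (0.51 log units; beyond the scatter) from compound 4 to compound 1, 1.3-fold (0.12 log units) apart, within the scatter of two such steps This shows that, across these four compounds, the two changes add up without visible interference in this one assay, but it does not show that either change would behave the same way on any other core, or with any other amine.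

The compounds shown leave open how a piperidine, a morpholine or a piperazine in place of diethylamino would read. They also leave open what a shorter or longer chain, or a larger group than methyl or benzyl on the oxygen, would do.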